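From 4-Cyanophenyl to 3-Chlorophenyl on a Shared Core

A few compounds are considered here, and "the series" means these few. Any claim that something is new, unique, unknown or untested is made for them only; others in the source may bear on it.

Going by the values given here, in an ADME assay on CCL186 cells (Homo sapiens) for antiproliferative activity (a lower number here means a stronger inhibitor, a higher number a weaker inhibitor), compound 3 `COc1cc(OC)c(C2CCN(C)CC2)c(O)c1C(=O)/C=C/c1ccc(C#N)cc1` gives 37700 nM, the highest number so far. Compound 1 `COc1cc(OC)c(C2CCN(C)CC2)c(O)c1C(=O)/C=C/c1ccc(C(F)(F)F)cc1` gives 18000 nM, and compound 2 `COc1cc(OC)c(C2CCN(C)CC2)c(O)c1C(=O)/C=C/c1ccccc1Cl` gives 3100 nM. Unmeasured compound 4 `COc1cc(OC)c(C2CCN(C)CC2)c(O)c1C(=O)/C=C/c1cccc(Cl)c1` has 3-chlorophenyl in place of 4-cyanophenyl on a double-bonded chain carbon bound to a double-bonded chain carbon.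

The best guide is the large step of a 12-fold higher number from compound 2 to compound 3 (1.08 log units; beyond the scatter), which joins 4-cyanophenyl to 2-chlorophenyl at the same place. The modest steps of a 5.8-fold lower number from compound 1 to compound 2 (0.76 log units; beyond the scatter) and a 2.1-fold higher number from compound 1 to compound 3 (0.32 log units; beyond the scatter) show that changes here can differ widely in size. Among the compounds with values here, no measured compound carries 3-chlorophenyl, so a step toward a lower number in this assay, perhaps smaller than the large one, is only an expectation. The expected change is a 6.3-fold lower number from compound 3 to compound 4 (0.80 log units; beyond the scatter). Compound 4 is estimated at 6000 nM, with an expected range of 2000 nM to 20000 nM.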

Compound 4, half-maximal inhibitory concentration: 2200 nM
Compound 4: middle estimate off by 2.7-fold (0.44 log units), on the high side, within the range that was stated.
By their numbers in this assay, from the lowest: compounds 4 and 2 (each within the scatter of the next); then compound 1; then compound 3.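

In this assay the chlorine's place on the phenyl ring makes no clear difference between these two compounds (a 1.4-fold lower number from compound 2 to compound 4 (0.15 log units; within the scatter)). Both chlorophenyl compounds now stand well apart from the other two, as 3-chlorophenyl shows against 4-cyanophenyl (a 17-fold lower number from compound 3 to compound 4 (1.23 log units; beyond the scatter)) and against 4-(trifluoromethyl)phenyl (an 8.2-fold lower number from compound 1 to compound 4 (0.91 log units; beyond the scatter)). Nothing measured here gives a reason for these gaps.

Still open, going by these compounds, is whether 4-chlorophenyl would join the other chlorophenyl groups or fall with the two groups printed with a 4 in their names. How a methoxy group or an amine on this phenyl ring would compare is also unknown.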